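This account rests on a few compounds, and the source may have more. Where it says the series, first, only, none or still open, it means among the compounds named here.

Compound 1 `CCCCC(CCO)n1cnc2c(Cl)ncnc21`: > 50000 nM
Compound 2 `CCCCC(CCO)n1cnc2c(N)ncnc21`: > 50000 nM
Compound 3 `CCCCC(CCO)n1cnc2cncnc21`: > 50000 nM

In a functional assay on HCT-116 cells (Homo sapiens) for antiproliferative activity, read by MTT assay, with a stated time of 48 h (a higher number here means a weaker inhibitor, a lower number a stronger inhibitor), compound 2 gives > 50000 nM, which is a limit and not a number. The entries for compound 1 and compound 3 are limits too, and all three compounds share the same one: the limit of > 50000 nM in this assay, at which 3 of the 3 values shown sit. Compound 2 therefore offers no measured potency as a starting point.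

Compound 4 `CCCCCC(CCO)n1cnc2c(N)ncnc21` differs from compound 2 in a single place: methyl in place of hydrogen on a saturated chain carbon, five bonds along the chain from an aromatic nitrogen. In words, this is methyl in place of hydrogen on a saturated chain carbon, five bonds along the chain from an aromatic nitrogen.

The measured steps give little guidance. They are a step that the two limits leave unreadable from compound 1 to compound 2, a step that the two limits leave unreadable from compound 1 to compound 3 and a step that the two limits leave unreadable from compound 2 to compound 3. All three change a group on an aromatic carbon, none changes the chain, and none has a size that could be carried over.

Since compound 2 gives only the limit > 50000 nM, no direction of change can be expected in this assay, and the estimated step that the limit leaves unreadable from compound 2 to compound 4 should not be read as a real shift. A reported limit is the most likely result.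

For compound 4 the expected value is 60000 nM, with an estimated range of 25000 nM to 120000 nM.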

Compound 4, half-maximal inhibitory concentration: > 50000 nM
Compound 4 gave a limit, no number; the forecaster's own chance of this, stated with the estimate: 85%; the middle value is on the limit's open side.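

Among these compounds, compound 2 and compound 4 both return a limit and not a number, so no step between them can be read, and the added methyl has no measurable size. The four compounds cannot be told apart: the limit of > 50000 nM in this assay, at which 4 of the 4 values shown sit.

Still open, on these data alone, is whether any change to this shared core gives a measured potency in this assay.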